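Swapping a Ring-Bearing Arm for a Carbamate Cap

The compounds below may be only part of what the source reports. "The series", "measured", "known", "first", "only" and "open" are said of these compounds alone.

Of the compounds shown here, two built on one shared core have been tested in a functional assay on SV5A8 cells (Homo sapiens) for cytotoxicity; a higher number here means a weaker inhibitor, a lower number a stronger inhibitor. Compound 1 `Cc1ccc2c(NCc3ccc(NC(=O)C4CCN(Cc5ccc(F)cc5)CC4)cc3)nc(N(C)C)nc2c1` gives only a limit of the assay, > 4820 nM. Compound 2 `Cc1ccc2c(NCc3ccc(NC(=O)C4CCN(Cc5ncc[nH]5)CC4)cc3)nc(N(C)C)nc2c1` likewise gives only a limit, > 20000 nM. The step that the two limits leave unreadable from compound 1 to compound 2 therefore cannot be read, since the value of compound 1 rests on the limit of > 4820 nM in this assay, at which 1 of the 2 values shown sits, and the value of compound 2 rests on (the limit of > 20000 nM in this assay, at which 1 of the 2 values shown sits).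

Compound 3 `Cc1ccc2c(NCc3ccc(NC(=O)C4CCN(C(=O)OC(C)(C)C)CC4)cc3)nc(N(C)C)nc2c1` differs from compound 2 by tert-butoxycarbonyl in place of (1H-imidazol-2-yl)methyl on an amine nitrogen in a ring. Within the data shown here, no measured step bears directly on this change; the single measured step, a step that the two limits leave unreadable from compound 1 to compound 2, is unreadable and gives neither size nor direction. Because compound 2 stands at > 20000 nM, compound 3 is also expected to register weakly in this assay. Compound 3 is estimated at 20000 nM, within 5000 nM to 60000 nM. The expected step from compound 2 to compound 3 is a number no higher from compound 2 to compound 3 (the limit leaves the size open), no change beyond the scatter.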

Compound 3, half-maximal inhibitory concentration: > 4820 nM
Compound 3 was reported as a limit (the forecaster's own chance of this, stated with the estimate: 75%); the middle value lies beyond the limit too.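

Among these compounds, compound 1, compound 2 and compound 3 each stand only as a limit in this assay, so no step among them can be read. The compounds shown leave open whether changing the group on the amine nitrogen in a ring alters the result in this assay at all.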